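Swapping one aryl group on a well-tolerated amide

This account rests on a few compounds, and the source may have more. Where it says the series, first, only, none or still open, it means among the compounds named here.

- compound 1 `COc1ccc(-c2cnc(NC(=O)c3ccccc3C)n2C)cc1`: > 100000 nM (a limit)
- compound 2 `COc1ccc(-c2cnc(NC(=O)c3ccc(F)cc3)n2C)cc1`: >= 50000 nM (a limit)

In a toxicity assay on THP-1 cells (Homo sapiens) for inhibition (a lower number here means that less compound is tolerated, a higher number that more compound is tolerated), compound 2 gives >= 50000 nM and this is a limit, not a number. Compound 1 gives > 100000 nM and this too is a limit. Compound 3 `COc1ccc(-c2cnc(NC(=O)c3cccc(C)c3)n2C)cc1` differs from compound 2 by one change: 3-methylphenyl in place of 4-fluorophenyl on a carbonyl carbon. Going by the values given here, the only measured step that bears on it is a step that the two limits leave unreadable from compound 1 to compound 2 and it offers no size to carry over. No step beyond the scatter is therefore expected in this assay. The expected step is a step that the limit leaves unreadable from compound 2 to compound 3. For compound 3 the estimated value is 100000 nM with an expected range from 40000 nM to 200000 nM and a limit is likely.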

Compound 3, half-maximal cytotoxic concentration: > 100000 nM
Compound 3: no number, only a limit; the forecaster's own chance of this, stated with the estimate: 85%; the middle value sits exactly at the limit.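

In this assay, going by these compounds alone, compound 1, compound 2 and compound 3 each give only a limit, and no step between them can be read. The compounds shown leave open at what concentration, if any, each would reach half-maximal toxicity.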